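A few compounds are considered here, and "the series" means these few. Any claim that something is new, unique, unknown or untested is made for them only; others in the source may bear on it.

Measured compounds:
compound 1 `CN(C)CCNc1ccnc2cc(OCc3ccc(F)cc3)ccc12`: 780 nM
compound 2 `CCCCOc1ccc2c(Cl)ccnc2c1`: 2570 nM
compound 3 `CN(C)CCCNc1ccnc2cc(OCc3ccc(F)cc3)ccc12`: 940 nM

In a functional assay on NCI-H1650 cells (Homo sapiens) for cytotoxicity, read by MTT assay, with a stated time of 48 h (on this read-out higher numbers stand for weaker inhibition and lower numbers for stronger inhibition), compound 2 gives the highest of the three numbers; the nearest of the others is compound 3, the furthest compound 1, both beyond the scatter. Compound 4 `Clc1ccnc2cc(OCCCc3ccccc3)ccc12` carries phenyl in place of methyl on a saturated chain carbon, three bonds along the chain from an oxygen on an aromatic ring, so that ethyl becomes benzyl when the cut is set one bond further out. Among the compounds with values here, the one measured step, a 1.2-fold higher number from compound 1 to compound 3 (0.08 log units; within the scatter), lies on the amine chain of compounds 1 and 3 and does not touch the ether chain; it gives no guide to this change. Within the data shown here, with no bearing precedent, the step is expected to stay within the scatter, with the direction open. Compound 4 is therefore estimated at 2000 nM, in the range 700 nM to 6000 nM, a step of a 1.3-fold lower number from compound 2 to compound 4 (0.11 log units; within the scatter).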

Compound 4, half-maximal inhibitory concentration: 630 nM
For compound 4 the middle estimate is 3.2-fold (0.50 log units) above the measured one, outside the stated range (below it).
By their numbers in this assay, from the lowest: compounds 4, 1 and 3 (each within the scatter of the next); then compound 2.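

In this assay, phenyl in place of methyl on a saturated chain carbon, three bonds along the chain from an oxygen on an aromatic ring, gives a 4.1-fold lower number from compound 2 to compound 4 (0.61 log units; beyond the scatter). This is the only step shown on the ether chain, and it shows that the number responds to a change at this position, which the step on the amine chain could not show. No measured evidence is at hand to explain it.

The compounds shown do not tell how a cyclohexyl or a pyridine ring would compare at this place, or a longer chain carrying the phenyl. Nor do they tell whether the step would hold with the amine chain of compound 1 in place of the chlorine.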